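Acetylation of a primary hydroxyl on a nitrophenyl oxadiazole sugar

The source may report more compounds than this note shows. Statements on the series, on what has been measured and on what is new or still open speak of the compounds shown alone.

Of the compounds shown here, two built on the same spiro-fused sugar core have been measured in a functional assay on HeLa cells (Homo sapiens) for antiproliferative activity, read by sulforhodamine B assay, with a stated time of 48 h; on this read-out higher numbers stand for weaker inhibition of growth and lower numbers for stronger inhibition of growth. Compound 1, `COc1cc(-c2nc(CO[C@@H]3O[C@H](CSc4ncn[nH]4)[C@H]4OC5(CCCC5)O[C@@H]34)no2)cc(OC)c1OC`, carries a trimethoxyphenyl on the oxadiazole and a triazolylthio group on the side chain; in this assay compound 1 gives 37000 nM. Compound 2, `O=[N+]([O-])c1ccc(-c2nc(CO[C@@H]3O[C@H](CO)[C@H]4OC5(CCCC5)O[C@@H]34)no2)cc1`, pairs a nitrophenyl with a free hydroxymethyl; in this assay compound 2 gives 15000 nM, which is the lower of the two numbers, and the gap to compound 1 lies beyond the usual scatter. Compound 3, `CC(=O)OC[C@H]1O[C@@H](OCc2noc(-c3ccc([N+](=O)[O-])cc3)n2)[C@@H]2OC3(CCCC3)O[C@@H]21`, keeps everything of compound 2 except for one change: acetyl in place of hydrogen on an oxygen on a saturated carbon, an acetyl in place of hydrogen on an oxygen on a saturated carbon. Going by the values given here, no measured pair in this set shows what such a change does on its own. Compound 3 is therefore expected to stay close to compound 2, with a step of no change at the digits printed from compound 2 to compound 3 (within the scatter) that need not reach beyond the scatter in either direction. On that basis compound 3 is estimated at 15000 nM, within a range from 6000 nM to 40000 nM.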

Compound 3, concentration for 50% growth inhibition: 17000 nM
Compound 3: middle estimate off by 1.1-fold (0.05 log units), on the low side, and the stated range covers the measured number.
By their numbers in this assay, from the lowest: compounds 2 and 3 (each within the scatter of the next); then compound 1.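

In this assay, going by these compounds alone, acetyl in place of hydrogen on an oxygen on a saturated carbon gives a 1.1-fold higher number from compound 2 to compound 3 (0.05 log units; within the scatter), the first single change in this set that can be read on its own. It shows that, with the nitrophenyl on the oxadiazole and the rest of the shared core held fixed, the free hydroxy is not required for a number of this size, since going from hydroxymethyl to acetoxymethyl leaves the read-out within the scatter. Nothing available here accounts for this outcome.

As far as these compounds go, with only this one replacement at the position, it remains open whether a different group on the same carbon, such as an amine, a carboxylic acid or a longer chain in place of the acetyl's methyl, would also stay within the scatter or would move the number beyond it. Within the data shown here, it is equally open whether the acetyl would behave the same way alongside the trimethoxyphenyl of compound 1, which differs from the other two compounds in more than one place, so no step to it can be read.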